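Benzyl versus phenyl on the piperazine-like ring nitrogen

A few compounds are considered here, and "the series" means these few. Any claim that something is new, unique, unknown or untested is made for them only; others in the source may bear on it.

Three analogues of the shared core have been measured in an assay on CHO cells for displacement of a labelled ligand from adenosine receptor A2b (Homo sapiens), read by scintillation counting, with a stated time of 75 min, in the presence of a further agent that is not named here; a higher number here means a weaker inhibitor, a lower number a stronger inhibitor. Compound 1 `CCCn1c(=O)[nH]c2nc(-c3ccc(S(=O)(=O)N4CCN(c5ccc(F)cc5)CC4)cc3)[nH]c2c1=O` gives 0.644 nM. Compound 2 `CCCn1c(=O)[nH]c2nc(-c3ccc(S(=O)(=O)N4CCN(Cc5cccc(Br)c5)CC4)cc3)[nH]c2c1=O` gives 0.148 nM. Compound 3 `CCCn1c(=O)[nH]c2nc(-c3ccc(S(=O)(=O)N4CCN(c5cccc(Br)c5)CC4)cc3)[nH]c2c1=O` gives 0.234 nM, which places compound 3 second highest of the three numbers, closest to compound 2 and furthest from compound 1. The step of a 2.8-fold lower number from compound 1 to compound 3 (0.44 log units; beyond the scatter) lies beyond the scatter, as does a 4.4-fold lower number from compound 1 to compound 2 (0.64 log units; beyond the scatter), whereas a 1.6-fold higher number from compound 2 to compound 3 (0.20 log units; within the scatter) lies within it.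

Compound 4 `CCCn1c(=O)[nH]c2nc(-c3ccc(S(=O)(=O)N4CCN(Cc5ccc(Br)c(F)c5)CC4)cc3)[nH]c2c1=O` differs from compound 3 by 4-bromo-3-fluorobenzyl in place of 3-bromophenyl on an amine nitrogen in a ring. Two things change at once: the 3-bromophenyl gives way to a group that, like that of compound 2, is joined through a benzyl carbon, and a fluorine is added to the ring. For the measured compounds named here, the only step that bears directly on the benzyl link is a 1.6-fold higher number from compound 2 to compound 3 (0.20 log units; within the scatter), within the scatter, and nothing among the measured compounds speaks to an added fluorine on that group. A small move in this assay toward a lower number, or none beyond the scatter, is therefore expected, estimated as a 1.4-fold lower number from compound 3 to compound 4 (0.14 log units; within the scatter). Compound 4 is estimated at 0.17 nM, with a range from 0.07 nM to 0.45 nM.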

Compound 4, inhibition constant: 0.473 nM
The estimate for compound 4 lay 2.8-fold (0.44 log units) below the measured number, outside the stated range (above it).
By their numbers in this assay, from the lowest: compounds 2 and 3 (each within the scatter of the next); then compounds 4 and 1 (each within the scatter of the next).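

The benzyl link alone does not set the number at this position: in this assay the 4-bromo-3-fluorobenzyl group gives a 2.0-fold higher number from compound 3 to compound 4 (0.31 log units; beyond the scatter), and the comparison with the 3-bromobenzyl group gives a 3.2-fold higher number from compound 2 to compound 4 (0.50 log units; beyond the scatter), so the substitution on the benzyl ring matters here. With a 1.4-fold lower number from compound 1 to compound 4 (0.13 log units; within the scatter), compound 4 and compound 1 cannot be told apart in this assay, although their groups differ in both link and ring substitution. No measurement at hand explains these steps.

Which of the two differences between the 3-bromobenzyl and 4-bromo-3-fluorobenzyl groups carries the step stays open, and a 4-bromobenzyl group would separate them. Also open, going by these compounds, is how this position responds to a benzyl ring bearing something other than halogen, such as a carboxylic acid or an amine.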